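The source may report more compounds than this note shows. Statements on the series, on what has been measured and on what is new or still open speak of the compounds shown alone.

Of the compounds shown here, three have been tested in an assay on isolated protein for inhibition of leukotriene B4 receptor 1 (Homo sapiens), tested at 10 uM; a lower number here means less inhibition, a higher number more inhibition at the concentration tested (going by the name of the read-out). Compound 1 `CC(=O)c1ccc(OCCCCC#N)cc1O` gives 0% in this assay. Compound 2 `C=CCc1cc(C(C)=O)c(O)cc1OCCCCCCCC#N` gives 88% in this assay, and compound 3 `CCc1cc(C(C)=O)c(O)cc1OCCCC(C)(C)C(N)=O` gives 92% in this assay. Among these three numbers, compound 2 stands second highest: its reading and that of compound 3 lie within the usual scatter of each other, so no order can be claimed for that pair, while the reading of compound 1 lies far below, beyond the scatter.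

Compound 4 `C#CCCCCOc1cc(O)c(C(C)=O)cc1CC=C` has not yet been measured. It differs from compound 2 in one place: ethynyl in place of 3-cyanopropyl on a saturated chain carbon, four bonds along the chain from an oxygen on an aromatic ring. The chain is thereby shortened and the nitrile is lost. Going by the values given here, no measured pair shows the effect of this exact change. The only shorter chain present, in compound 1 with 0%, gives a much weaker reading than compound 2, but compound 1 also lacks the allyl group, so the comparison is not clean. A loss of inhibition is nevertheless expected, and the step of a number 43 percentage points lower from compound 2 to compound 4 (beyond the scatter) is estimated as a clear drop. Compound 4 is expected to reach about 45%, within a range from 10% to 80%.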

Compound 4, a percentage reported as inhibition, at one concentration (the size of the read-out at that concentration, not a potency): 74%
Compound 4: the middle estimate sits 29 percentage points below what was measured, within the range that was stated.
By their numbers in this assay, from the lowest: compound 1; then compound 4; then compounds 2 and 3 (each within the scatter of the next).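

In this assay, putting ethynyl in place of 3-cyanopropyl, on a saturated chain carbon four bonds along the chain from an oxygen on an aromatic ring, gives a number 14 percentage points lower from compound 2 to compound 4 (beyond the scatter). The step is real but modest, so at this position inhibition does not depend on the nitrile, and a chain ending in a triple bond between carbons keeps much of the reading. No measurement in hand explains why the reading falls.

The compounds shown do not separate the effect of the shorter chain from that of losing the nitrile, as both change in this single step. On these data alone, how a chain of similar length ending in a nitrile, a carboxylic acid or an amine would read at this position remains open.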